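The compounds below may be only part of what the source reports. "The series", "measured", "known", "first", "only" and "open" are said of these compounds alone.

Measured in a functional assay on SEM cells (Homo sapiens) for inhibition, read by MTT assay, with a stated time of 72 h; a lower number here means a stronger inhibitor, a higher number a weaker inhibitor:
- compound 1 `C=C(Br)C(=O)Nc1cccc(/C=C/C(=O)Nc2ccc(F)cc2)c1`: 8400 nM
- compound 2 `C=C(Br)C(=O)Nc1cccc(/C=C/C(=O)Nc2ccc(Cl)cc2)c1`: 1190 nM
- compound 3 `C=C(Br)C(=O)Nc1cccc(/C=C/C(=O)NCc2ccc(C)cc2)c1`: 1300 nM

Of these three numbers, the second highest belongs to compound 3. Its nearest neighbour shows a 1.1-fold higher number from compound 2 to compound 3 (0.04 log units; within the scatter), while the furthest shows a 6.5-fold lower number from compound 1 to compound 3 (0.81 log units; beyond the scatter).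

Compound 4 `C=C(Br)C(=O)Nc1cccc(/C=C/C(=O)Nc2ccc(OC)cc2)c1` differs by 4-methoxyphenyl in place of 4-methylbenzyl on an amide-type nitrogen. Within the data shown here, no measured compound carries the methoxy group, so only indirect evidence applies. Compound 4 has a substituted phenyl on that nitrogen, as do compounds 1 and 2, and the substituent alone gave a 7.1-fold lower number from compound 1 to compound 2 (0.85 log units; beyond the scatter). Replacing such a phenyl group with 4-methylbenzyl gave steps both within and beyond the scatter, as seen above. A modest move to a higher number in this assay is therefore expected, with its size uncertain. The expected change is a 2.2-fold higher number from compound 3 to compound 4 (0.33 log units; beyond the scatter). For compound 4 the estimated value is 2800 nM, with an expected range of 900 nM to 7500 nM.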

Compound 4, half-maximal inhibitory concentration: 70 nM
For compound 4 the middle estimate is 40-fold (1.60 log units) above the measured one; the measured number lies below the stated range.
By their numbers in this assay, from the lowest: compound 4; then compounds 2 and 3 (each within the scatter of the next); then compound 1.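

In this assay, 4-methoxyphenyl on the amide-type nitrogen stands apart from every earlier group there: replacing 4-methylbenzyl gives a large step (a 19-fold lower number from compound 3 to compound 4 (1.27 log units; beyond the scatter)), and methoxy gives large steps in place of chloro (a 17-fold lower number from compound 2 to compound 4 (1.23 log units; beyond the scatter)) and fluoro (a 120-fold lower number from compound 1 to compound 4 (2.08 log units; beyond the scatter)). The earlier change of substituent on this phenyl, chloro in place of fluoro, had produced only a modest step (a 7.1-fold lower number from compound 1 to compound 2 (0.85 log units; beyond the scatter)), so a single substituent here can shift the number much further than that step showed. No measurement at hand explains this shift.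

The compounds shown leave open whether an ethoxy, hydroxyl or dimethylamino group in place of methoxy would keep this level. They also leave open whether 4-methoxybenzyl on the same nitrogen would match compound 4.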